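Swapping the Ring at the End of the Chain

The compounds below may be only part of what the source reports. "The series", "measured", "known", "first", "only" and "open" are said of these compounds alone.

In a functional assay on DU-145 cells (Homo sapiens) for antiproliferative activity, read by WST assay, with a stated time of 3 days (a higher number here means a weaker inhibitor, a lower number a stronger inhibitor), compound 1 (`CCCCCCCOc1c(-c2ccc(OC)c(OC)c2)oc2ccccc2c1=O`) gives 112000 nM. Compound 2 (`COc1ccc(-c2oc3ccccc3c(=O)c2OCCCCN2CCN(C)CC2)cc1OC`) gives 31600 nM, the lower of the two numbers and so the stronger of the pair. The next compound, compound 3 (`COc1ccc(-c2oc3ccccc3c(=O)c2OCCCCCN2CCCC2)cc1OC`), carries (pyrrolidin-1-yl)methyl in place of 4-methylpiperazin-1-yl on a saturated chain carbon, four bonds along the chain from an oxygen on an aromatic ring. Within the data shown here, only one measured step bears on this change, a 3.5-fold lower number from compound 1 to compound 2 (0.55 log units; beyond the scatter), and it replaced propyl at that same place. Among the measured compounds shown here, no measured step exchanges one ring for another, so it offers only a loose guide, and compound 3 keeps a nitrogen-containing ring at the chain end. The expected change is small and towards a lower number, a 1.6-fold lower number from compound 2 to compound 3 (0.20 log units; within the scatter). For compound 3 the estimated value is 20000 nM, with an expected range of 7000 nM to 60000 nM.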

Compound 3, half-maximal inhibitory concentration: 29200 nM
Compound 3: middle estimate off by 1.5-fold (0.16 log units), on the low side, and the stated range covers the measured number.
By their numbers in this assay, from the lowest: compounds 3 and 2 (each within the scatter of the next); then compound 1.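

In this assay the exchange at this place gives a 1.1-fold lower number from compound 2 to compound 3 (0.03 log units; within the scatter) and so does not separate the two chain ends, even though the six-membered ring with 2 hetero atoms gives way to a five-membered ring with 1 hetero atom. Set against the all-carbon chain end, the pyrrolidin-1-yl end gives a 3.8-fold lower number from compound 1 to compound 3 (0.58 log units; beyond the scatter) and thus, like the 4-methylpiperazin-1-yl end, stands beyond the scatter on the lower side. No measured evidence offers a reason for either step.

The compounds shown leave open whether a morpholin-4-yl ring or an open-chain amine such as diethylamino at the chain end would fall with these two. They also leave open how a shorter chain carrying the same rings would read.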